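From Methoxy to Hydroxy on the Phenoxy Group

This account rests on a few compounds, and the source may have more. Where it says the series, first, only, none or still open, it means among the compounds named here.

In a functional assay for inhibition, with Homo sapiens as the target (on this read-out higher numbers stand for weaker binding and lower numbers for tighter binding), compound 2 (`COc1ccccc1OC(C)(C)C1OCC(C/C=C\CCC(=O)O)C(c2cccnc2)O1`) gives 224 nM as the lower of two numbers, while compound 1 (`CC(C)(C)c1ccc(OC(C)(C)C2OCC(C/C=C\CCC(=O)O)C(c3cccnc3)O2)cc1`) gives 1910 nM in the same read-out. Compound 3 (`CC(C)(Oc1ccccc1O)C1OCC(C/C=C\CCC(=O)O)C(c2cccnc2)O1`) is still unmeasured and differs from compound 2 by hydrogen in place of methyl on an oxygen on an aromatic ring with hydrogen in place of methyl on an oxygen on an aromatic ring. For the measured compounds named here, the one measured step (an 8.5-fold lower number from compound 1 to compound 2 (0.93 log units; beyond the scatter)) put 2-methoxyphenyl in place of 4-(tert-butyl)phenyl, so it offers only a loose guide. A smaller step is expected here (a 1.7-fold lower number from compound 2 to compound 3 (0.24 log units; within the scatter)) that leans toward a lower number and may stay within the scatter. For compound 3 the estimated value is 130 nM with an expected range from 35 nM to 480 nM in this read-out.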

Compound 3, dissociation constant: 95.5 nM
Compound 3: middle estimate off by 1.4-fold (0.13 log units), on the high side, and the stated range covers the measured number.
By their numbers in this assay, from the lowest: compound 3; then compound 2; then compound 1.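

Changing 2-methoxyphenyl to 2-hydroxyphenyl gives a 2.3-fold lower number from compound 2 to compound 3 (0.37 log units; beyond the scatter) in this assay, so the loss of a single methyl on this oxygen moves the number beyond the scatter, something the earlier exchange of whole phenyl groups could not show. Measured against the 4-(tert-butyl)phenyl group, the 2-hydroxyphenyl group gives a 20-fold lower number from compound 1 to compound 3 (1.30 log units; beyond the scatter), a large step. Nothing available explains why the number falls with this change.

From the compounds shown here alone, whether an amine or an ethoxy group in place of the hydroxy would keep the number this low remains open.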